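Three limit values and a nitrophenyl switch

The compounds below may be only part of what the source reports. "The series", "measured", "known", "first", "only" and "open" are said of these compounds alone.

Measured so far:
- Compound 1, `C[C@@H]1CCN(c2cc(-c3ccccc3)nc3ncnn23)C[C@@H]1N(C)c1ncnc2[nH]ccc12`. In a functional assay on HGC-27 cells (Homo sapiens) for inhibition, read by MTT assay, with a stated time of 72 h (on this read-out higher numbers stand for weaker inhibition and lower numbers for stronger inhibition), compound 1 gives > 100000 nM, which is a limit of the assay and not a number.
- Compound 2, `Cc1nc2nc(SCc3ccc(Cl)cc3)nn2c(N2CC[C@@H](C)[C@@H](N(C)c3ncnc4[nH]ccc34)C2)c1C`. In this assay compound 2 gives > 100000 nM, again a limit.
- Compound 3, `Cc1cc(N2CC[C@@H](C)[C@@H](N(C)c3ncnc4[nH]ccc34)C2)n2nc(SCc3csc4ccc(Cl)cc34)nc2n1`. In this assay compound 3 gives > 100000 nM, also a limit.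

Compound 3 therefore stands nowhere in particular among the numbers shown: every value is the same limit, and the limit of > 100000 nM in this assay, at which 3 of the 3 values shown sit, tells that all three sit there. Among the measured compounds shown here, no two measured compounds differ in only one place, so no step size can be read from what has been measured; the three limits can only be said to agree with one another.

The unmeasured compound 4, `Cc1cc(N2CC[C@@H](C)[C@@H](N(C)c3ncnc4[nH]ccc34)C2)n2nc(SCc3ccc([N+](=O)[O-])cc3)nc2n1`, keeps the whole of compound 3 apart from one change: 4-nitrophenyl in place of 5-chloro-1-benzothiophen-3-yl on a saturated chain carbon bound to a sulfur. For the measured compounds named here, because the limit of > 100000 nM in this assay, at which 3 of the 3 values shown sit, shows every compound so far at the limit, the step is expected to be none beyond the scatter, and the step of a number no higher from compound 3 to compound 4 (the limit leaves the size open) is estimated accordingly. Compound 4 is expected to give roughly 100000 nM, with a plausible range from 30000 nM to 300000 nM, and most likely the assay will again report only a limit.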

Compound 4, half-maximal inhibitory concentration: 29400 nM
For compound 4 the middle estimate is 3.4-fold (0.53 log units) above the measured one; measured number below the stated range.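

Among the compounds shown here, the group on this saturated chain carbon bound to a sulfur can change the read-out, which the earlier compounds could not show. In this assay, for the compounds shown here, 4-nitrophenyl in place of 5-chloro-1-benzothiophen-3-yl gives an at least 3.4-fold lower number from compound 3 to compound 4 (0.53 log units; beyond the scatter), and compound 4, at 29400 nM, is the first compound here with a measured number rather than a limit. The true size of the step remains open because compound 3 carries only a limit, as do the other two earlier compounds: the limit of > 100000 nM in this assay, at which 3 of the 4 values shown sit.

The compounds shown cannot separate the parts of this change, since the fused ring system and its chlorine leave and the nitro group enters in a single step, so it remains unclear which of these matters. As far as these compounds go, it also remains open whether an amine, a nitrile or a carboxylic acid in place of the nitro group would give a lower number, a higher number or the same number in this assay, and whether the same change would act alike on the core of compound 1.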